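Aryl change on the shared core: expectation for compound 3

This account rests on a few compounds, and the source may have more. Where it says the series, first, only, none or still open, it means among the compounds named here.

Measured so far:
compound 1 `Cc1cc(NC(=O)Cn2nnc(-c3ccccc3)n2)n(C2CCCCC2)n1` — in an assay on HEK293 cells for activation of Kir3.1/Kir3.2 (Homo sapiens), read by thallium flux (a lower number here means a smaller maximal response, a higher number a larger maximal response), compound 1 gives 92%
compound 2 `Cc1cc(NC(=O)Cn2nnc(-c3ccccc3F)n2)n(C2CCCCC2)n1` — in this assay compound 2 gives 88%

Among the measured compounds shown here, compound 2 holds the lower of the two numbers, with compound 1 within the scatter of it; the only measured step, a number 4 percentage points lower from compound 1 to compound 2 (within the scatter), is fluoro in place of hydrogen on an aromatic carbon and stays within the scatter. Compound 3 `Cc1cccc(-c2nnn(CC(=O)Nc3cc(C)nn3C3CCCCC3)n2)c1` carries 3-methylphenyl in place of 2-fluorophenyl on an aromatic carbon. For the measured compounds named here, no measured step covers a methyl on this ring, and the one step on this phenyl was within the scatter, so no change beyond the scatter is expected in this assay. For compound 3 the estimate is 88%, range 74% to 100%. The expected step from compound 2 is no change at the digits printed from compound 2 to compound 3 (within the scatter).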

Compound 3, largest response reached (Emax), in percent of the reference or control that the assay uses: 93%
Estimate against measurement, compound 3: 5 percentage points below; low and high end bracket the measured number.
By their numbers in this assay, from the lowest: compounds 2, 1 and 3 (each within the scatter of the next).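

In this assay, a methyl on the phenyl ring behaves as the fluoro did, with a number 1 percentage points higher from compound 1 to compound 3 (within the scatter) for this change. Exchanging 2-fluorophenyl for 3-methylphenyl gives a number 5 percentage points higher from compound 2 to compound 3 (within the scatter), so all three aryl groups on this carbon of the shared core lie within the scatter of one another. No available data offer an explanation for this result.

Going by these compounds, whether an amine or a carboxylic acid on the phenyl ring would move the maximal response beyond the scatter remains open. On these data alone, the effect of exchanging the cyclohexyl group for a longer chain also remains open.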